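Swapping hydroxy for chloro in a cytotoxicity test

The compounds below may be only part of what the source reports. "The series", "measured", "known", "first", "only" and "open" are said of these compounds alone.

Compound 1 `COc1ccc(/C=C2\C(=O)N(c3c(Cl)cccc3Cl)c3ccccc32)cc1OC` gives > 100 ug/mL as a limit
Compound 2 `O=C1/C(=C\c2cc3ccccc3nc2Cl)c2ccccc2N1c1c(Cl)cccc1Cl` gives "not determined" (no result reported) as its entry
Compound 3 `O=C1/C(=C\c2ccc(O)cc2)c2ccccc2N1c1c(Cl)cccc1Cl` gives 30 ug/mL as a measured number

Among the compounds with values here, in a functional assay on L132 cells (Homo sapiens) for cytotoxicity, read by MTT assay, with a stated time of 72 h (on this read-out lower numbers stand for an effect already at smaller amounts and higher numbers for an effect only at larger amounts of compound), compound 3 gives 30 ug/mL as the only true number among the three. Compound 1 gives > 100 ug/mL as its result, and this is a limit, not a number. Compound 2 has no result to compare.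

The next molecule is compound 4 `O=C1/C(=C\c2ccc(Cl)cc2)c2ccccc2N1c1c(Cl)cccc1Cl`, which carries chloro in place of hydroxy on an aromatic carbon, para to a large group (chloro in place of hydroxy on an aromatic carbon). Within the data shown here, no two measured compounds differ in one place only, so nothing yet shows what this swap does in this assay. The expectation therefore stays close to compound 3 at 30 ug/mL and is deliberately wide. No step beyond the usual scatter is expected, with the estimated step of a 1.3-fold higher number from compound 3 to compound 4 (0.12 log units; within the scatter) as the central guess. Compound 4 is estimated at 40 ug/mL with an expected range from 12 ug/mL to 100 ug/mL in this test.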

Compound 4, concentration for half-maximal effect: 9 ug/mL
Compound 4: the middle estimate sits 4.4-fold (0.65 log units) above what was measured; the whole stated range lies above it.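

Within the data shown here, replacing 4-hydroxyphenyl with 4-chlorophenyl gives the first readable single-place comparison in this assay: a 3.3-fold lower number from compound 3 to compound 4 (0.52 log units; beyond the scatter). A lower number here means that less compound is needed for the cytotoxic effect, so this ring position, para to a large group, can influence the result. The step rests on two measured numbers rather than a limit, and the test's upper limit does not affect this comparison: the limit of > 100 ug/mL in this assay, at which 1 of the 4 values shown sits.

This single pair cannot separate the loss of hydroxy, with its hydrogen-bond donor and acceptor, from the arrival of chloro, and it does not explain the change. An amine or a carboxylic acid at the same position would help show whether the trend extends beyond these two groups.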